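From a ring to an acetyl on the ether chain

The source may report more compounds than this note shows. Statements on the series, on what has been measured and on what is new or still open speak of the compounds shown alone.

Of the compounds shown here, three sharing one core have been measured in an assay on HT-29 cells for inhibition of Methylated-DNA--protein-cysteine methyltransferase (Homo sapiens); on this read-out higher numbers stand for weaker inhibition and lower numbers for stronger inhibition. Compound 1 `C=C(CC)COc1nc(N)nc2[nH]cnc12` gives 16000 nM, compound 2 `C#CCOc1nc(N)nc2[nH]cnc12` gives 20000 nM, and compound 3 `Nc1nc(OCC2=CCCCC2)c2nc[nH]c2n1` gives 1600 nM, the lowest of the three numbers. The steps of a 10-fold lower number from compound 1 to compound 3 (1.00 log units; beyond the scatter) and a 13-fold lower number from compound 2 to compound 3 (1.10 log units; beyond the scatter) both show that the cyclohex-1-en-1-yl group goes with a clearly lower number than a short chain, whereas a 1.3-fold higher number from compound 1 to compound 2 (0.10 log units; within the scatter) separates the two short chains by little. Compound 4 `CC(=O)COc1nc(N)nc2[nH]cnc12` carries acetyl in place of cyclohex-1-en-1-yl on a saturated chain carbon bound to an oxygen on an aromatic ring. This change removes the very group that set compound 3 apart, and the two steps that bear on it both ran in the lowering direction, so a step of similar size back upward is expected, with an 11-fold higher number from compound 3 to compound 4 (1.05 log units; beyond the scatter). Going by the values given here, the acetyl group has no measured counterpart here, so the expectation rests on compounds 1 and 2 alone. Compound 4 is therefore estimated at 18000 nM in this assay, with a plausible range from 5000 nM to 60000 nM.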

Compound 4, half-maximal inhibitory concentration: 192000 nM
Estimate against measurement, compound 4: 11-fold (1.03 log units) below; the measured number lies above the stated range.
By their numbers in this assay, from the lowest: compound 3; then compounds 1 and 2 (each within the scatter of the next); then compound 4.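

In this assay, going by these compounds alone, the range at this position proves wider than the earlier compounds showed, with a 120-fold higher number from compound 3 to compound 4 (2.08 log units; beyond the scatter) marking the widest gap seen so far. Compounds 1 and 2 had suggested that small groups on this saturated chain carbon give much the same result, but acetyl stands apart from both, with a 9.6-fold higher number from compound 2 to compound 4 (0.98 log units; beyond the scatter) and a 12-fold higher number from compound 1 to compound 4 (1.08 log units; beyond the scatter), so group size alone does not order these four compounds. The data shown offer no independent evidence that would explain the result.

From the compounds shown here alone, whether the higher number of compound 4 goes with the entering oxygen or with the particular shape of acetyl stays open. Isopropenyl, the all-carbon counterpart of acetyl, would separate these two readings, while a hydroxyethyl group or a carboxylic acid would show whether other oxygen-bearing groups follow compound 4.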